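Ethoxycarbonyl to Carbamoyl: One Measured Step, One Expected

The source may hold more compounds than are shown below. What is called first, only, known or untested is meant among the compounds shown, and "the series" means these compounds.

Measured compounds in a functional assay on HeLa cells (Homo sapiens); a lower number here means that less compound is needed, a higher number that more compound is needed for the effect:
- compound 1 `CCOC(=O)c1cc(CCl)[nH]n1`: in this assay compound 1 gives > 100 ug/mL, which is a limit of the assay.
- compound 2 `NC(=O)c1cc(CCl)[nH]n1`: compound 2 gives > 100 ug/mL, again a limit of the assay.
- compound 3 `CCOC(=O)c1cc(CCl)nn1C1O[C@@H](COC(C)=O)[C@H](OC(C)=O)[C@@H](OC(C)=O)[C@@H]1OC(C)=O`: compound 3 gives 40 ug/mL.

Compound 4 `CC(=O)OC[C@@H]1OC(n2nc(CCl)cc2C(N)=O)[C@@H](OC(C)=O)[C@H](OC(C)=O)[C@H]1OC(C)=O` has not been measured. It differs from compound 3 by amino in place of ethoxy on a carbonyl carbon. The same change, word for word at the same place, is found between compound 1 and compound 2: amino in place of ethoxy on a carbonyl carbon. There it made a step that the two limits leave unreadable from compound 1 to compound 2, unreadable because both values sit at the limit of > 100 ug/mL in this assay, at which 2 of the 3 values shown sit. The difference between the core of compound 1 and the core of compound 3 is not broken down here.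

For the measured compounds named here, since the only measured instance of this change yields no size, the expectation for compound 4 rests on compound 3 alone, at 40 ug/mL. The step is estimated as a 1.5-fold higher number from compound 3 to compound 4 (0.18 log units; within the scatter), with room for a modest loss. Compound 4 is therefore expected at 60 ug/mL, within 25 ug/mL to 150 ug/mL.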

Compound 4, concentration for half-maximal effect: 18 ug/mL
Estimate against measurement, compound 4: 3.3-fold (0.52 log units) above; measured number below the stated range.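

In this assay, amino in place of ethoxy on a carbonyl carbon gives a 2.2-fold lower number from compound 3 to compound 4 (0.35 log units; beyond the scatter) on the core of compound 3. On the core of compound 1 the same change cannot be read, as compound 1 and compound 2 both sit at a limit of the assay: the limit of > 100 ug/mL in this assay, at which 2 of the 4 values shown sit. The series therefore holds one sized instance of this change, and it does not show whether that size or direction carries from one core to another.

The compounds shown leave open how a carboxylic acid or a dimethylamino group on that carbonyl carbon would read on the core of compound 3. They also leave open which part of that core the step depends on.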